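A few compounds are considered here, and "the series" means these few. Any claim that something is new, unique, unknown or untested is made for them only; others in the source may bear on it.

Measured compounds:
Compound 1 `O=C(Nc1cc(C(F)(F)F)ccc1N1CCCCC1)c1ccccc1` gives "not active" (no number reported) in a functional assay on HL-60 cells (Homo sapiens) for cytotoxicity, read by MTT assay, with a stated time of 48 h; on this read-out higher numbers stand for weaker inhibition and lower numbers for stronger inhibition.
Compound 2 `CCN(CC)c1ccc(C(F)(F)F)cc1NC(=O)c1cccnc1` gives 71000 nM in this assay.
Compound 3 `O=C(Nc1cc(C(F)(F)F)ccc1N1CCCCC1)c1cccnc1Cl` gives "not active" (no number reported) in this assay.

Compound 2 stands alone among these three with an actual number; for compound 1 and for compound 3 only an absence of activity was reported, without a figure. The number for compound 2 is itself a high half-maximal inhibitory concentration, so the reference point is already weak inhibition.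

Compound 4 `O=C(Nc1cc(C(F)(F)F)ccc1NC1CCCCC1)c1cccnc1` is not yet measured. It differs from compound 2 by cyclohexylamino in place of diethylamino on an aromatic carbon. For the measured compounds named here, no two measured compounds differ at a single place, so no measured step guides this change, and the expectation rests on compound 2 alone. Because compound 2 gives 71000 nM in this assay, the step from compound 2 to compound 4 is expected to be a 1.4-fold higher number from compound 2 to compound 4 (0.15 log units; within the scatter), a modest move toward weaker inhibition, perhaps no more than the usual scatter. Compound 4 is therefore expected to give about 100000 nM, within 30000 nM to 300000 nM, with a substantial chance that only an absence of activity is reported.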

Compound 4, half-maximal inhibitory concentration: 48300 nM
For compound 4 the middle estimate is 2.1-fold (0.32 log units) above the measured one; low and high end bracket the measured number.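

In this assay, for the compounds shown here, putting cyclohexylamino in place of diethylamino on this aromatic carbon gives a 1.5-fold lower number from compound 2 to compound 4 (0.17 log units; within the scatter), the first step that can be read at this position. The incoming group adds a six-membered non-aromatic ring and a hydrogen-bond donor, yet the read-out stays within the usual scatter, and both compounds remain in the range of weak inhibition. No measurement at hand bears on why the two values stay so close.

The ring and the donor enter together, and the compounds shown do not separate them; an open-chain butylamino group or a cyclohexyloxy group at the same carbon would pull the two apart. Also open, going by these compounds, is whether a more different group here, such as a carboxylic acid or a nitrile, would shift the number beyond the scatter.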